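Cyclopentylurea in place of trifluoromethyl on the sulfonyl ring

The compounds below may be only part of what the source reports. "The series", "measured", "known", "first", "only" and "open" are said of these compounds alone.

Measured compounds:
compound 1 `O=C(Nc1ccc(-c2noc(-c3cccc(NS(=O)(=O)c4ccc(C(F)(F)F)cc4)c3)n2)c(Cl)c1)c1cccnc1`, in a functional assay on MDA-MB-231 cells (Homo sapiens) for antiproliferative activity, read by MTT assay, with a stated time of 72 h (on this read-out higher numbers stand for weaker inhibition and lower numbers for stronger inhibition), compound 1 gives > 10000 nM, a limit of the assay.
compound 2 `COc1cccc(S(=O)(=O)Nc2cccc(-c3nc(-c4ccc(NC(=O)c5cccnc5)cc4Cl)no3)c2)c1`, in this assay compound 2 gives > 10000 nM, again a limit.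
compound 3 `CC(=O)Nc1ccc(S(=O)(=O)Nc2cccc(-c3nc(-c4ccc(NC(=O)c5cccnc5)cc4Cl)no3)c2)cc1C`, in this assay compound 3 gives > 10000 nM, also a limit.

Compound 1 therefore stands only at a limit of this assay, not at a number. The same holds for the two neighbours that differ from it in the group on the sulfonyl sulfur, so the step that the two limits leave unreadable from compound 1 to compound 2 and the step that the two limits leave unreadable from compound 1 to compound 3 cannot be read; the pair a step that the two limits leave unreadable from compound 2 to compound 3 is unreadable too, a situation summed up by the limit of > 10000 nM in this assay, at which 3 of the 3 values shown sit.

Compound 4 `O=C(Nc1ccc(S(=O)(=O)Nc2cccc(-c3nc(-c4ccc(NC(=O)c5cccnc5)cc4Cl)no3)c2)cc1)NC1CCCC1` changes compound 1 in the same region: (cyclopentylcarbamoyl)amino in place of trifluoromethyl on an aromatic carbon. Within the data shown here, no measured step bears readably on this change, since every neighbour sits at the limit. The change is expected to amount to a step that the limit leaves unreadable from compound 1 to compound 4, that is, to leave compound 4 where its neighbours are. Compound 4 is estimated at 15000 nM in this assay. The expected lower end for compound 4 is 4000 nM. The expected upper end for compound 4 is 60000 nM.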

Compound 4, half-maximal inhibitory concentration: > 10000 nM
Compound 4 ended at the assay's limit; the forecaster's own chance of this, stated with the estimate: 85%; the middle value does not contradict the limit.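

In this assay compound 4 gives > 10000 nM, a limit and not a number, so the step between compound 1 and compound 4 cannot be read, and neither can any other step here: the limit of > 10000 nM in this assay, at which 4 of the 4 values shown sit. The compounds shown leave open whether any group on the sulfonyl ring gives a readable value in this assay, and how far these groups differ.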